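The source may hold more compounds than are shown below. What is called first, only, known or untested is meant among the compounds shown, and "the series" means these compounds.

Working notes on the series, followed in a functional assay on the whole organism (strain Sprague-Dawley) for inhibition, with Rattus norvegicus as the target; a lower number here means that less compound is needed, a higher number that more compound is needed for the effect.

Compound 1 `c1cc2ncc(-c3nn[nH]n3)cc2cc1OC1CCCCC1` gives 5 mg/kg. Compound 2 `O=C(O)c1cnc2ccc(OC3CCCCC3)cc2c1` gives > 25 mg/kg, which is a limit of the assay and not a number. For the measured compounds named here, the single measured step, an at least 5.0-fold higher number from compound 1 to compound 2 (0.69 log units; beyond the scatter), runs up to that limit, (the limit of > 25 mg/kg in this assay, at which 1 of the 3 values shown sits). Compound 3 `CC(C)c1cccc2c(=O)c(-c3nn[nH]n3)c[nH]c12` gives 1.25 mg/kg, the lowest of the two numbers shown; its nearest neighbour is compound 1, whose number stands higher by a gap beyond the scatter.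

Compound 4 `O=c1c(-c2nn[nH]n2)c[nH]c2c(Cl)cccc12` differs from compound 3 in one place: chloro in place of isopropyl on an aromatic carbon. The only measured step concerns the exchange of carboxy for 2H-tetrazol-5-yl, a part of the molecule that compound 4 keeps unchanged, so no measured step bears on the present change, and its direction cannot be read from the numbers shown. The step from compound 3 is therefore expected to stay within the scatter, a 1.2-fold higher number from compound 3 to compound 4 (0.08 log units; within the scatter). Compound 4 is estimated at 1.5 mg/kg, with an expected range from 0.5 mg/kg to 5 mg/kg.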

Compound 4, minimum effective dose: 0.078 mg/kg
The estimate for compound 4 lay 19-fold (1.28 log units) above the measured number; measured number outside the range, below it.
By their numbers in this assay, from the lowest: compound 4; then compound 3; then compound 1. At a limit, above all of these: compound 2.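

In this assay, for the compounds shown here, the place on the aromatic carbon, ortho to a fused ring and meta to a fused ring, proves highly sensitive to its substituent: chloro in place of isopropyl gives a 16-fold lower number from compound 3 to compound 4 (1.20 log units; beyond the scatter) and is the first measured step at this position. The earlier step concerned only the exchange of carboxy for 2H-tetrazol-5-yl, so it gave no hint that this place could move the number so strongly. Nothing available here accounts for the size of the step.

This single pair cannot separate the gain of chlorine from the loss of isopropyl. On these data alone, whether a methyl, a methoxy or an amine at the same place would give a similar number remains open, as does whether chloro would act the same way on the core of compound 1.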